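This account rests on a few compounds, and the source may have more. Where it says the series, first, only, none or still open, it means among the compounds named here.

Of the compounds shown here, three built on one shared core have been tested in a functional assay on PC-3 cells (Homo sapiens) for antiproliferative activity, read by MTT assay, with a stated time of 72 h; on this read-out lower numbers stand for stronger inhibition and higher numbers for weaker inhibition. In this assay compound 1 `C=CC(=O)Nc1cc2c(N3CCc4ccccc43)ncnc2cc1O[C@@H]1CCOC1` gives 2710 nM. In this assay compound 2 `COc1cc2ncnc(N3CCCc4ccccc43)c2cc1NC(=O)C=C(C)C` gives 6130 nM. In this assay compound 3 `C/C=C/C(=O)Nc1cc2c(N3CCCc4ccccc43)ncnc2cc1OC` gives 7520 nM, the highest of the three numbers; its gap to compound 2 is within the usual scatter, whereas its gap to compound 1 lies beyond it. Within the data shown here, the step of a 1.2-fold higher number from compound 2 to compound 3 (0.09 log units; within the scatter) is the only measured step that changes the chain on the carbonyl carbon.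

Compound 4 `CC/C=C/C(=O)Nc1cc2c(N3CCCc4ccccc43)ncnc2cc1OC` has not yet been measured. It differs from compound 3 by methyl in place of hydrogen on a saturated chain carbon bound to a double-bonded chain carbon. Because the related step of a 1.2-fold higher number from compound 2 to compound 3 (0.09 log units; within the scatter) stayed within the scatter, a further small change to the same chain is expected to give no step beyond the scatter in this assay. The step of a 1.0-fold lower number from compound 3 to compound 4 (0.00 log units; within the scatter) is therefore the expectation. Compound 4 is expected to give about 7500 nM, most likely somewhere between 3000 nM and 19000 nM.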

Compound 4, half-maximal inhibitory concentration: 6310 nM
Compound 4: middle estimate off by 1.2-fold (0.08 log units), on the high side; low and high end bracket the measured number.
By their numbers in this assay, from the lowest: compound 1; then compounds 2, 4 and 3 (each within the scatter of the next).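

In this assay, methyl in place of hydrogen on a saturated chain carbon bound to a double-bonded chain carbon, which turns prop-1-en-1-yl into but-1-en-1-yl, gives a 1.2-fold lower number from compound 3 to compound 4 (0.08 log units; within the scatter) and so leaves the number within the scatter. Moving from 2-methylprop-1-en-1-yl to but-1-en-1-yl on the carbonyl carbon gives a 1.0-fold higher number from compound 2 to compound 4 (0.01 log units; within the scatter), so all three chains shown at this position now read alike, with each pair of compounds within the scatter. No measurement shown here bears on why these chains give such similar numbers.

Still open, from the compounds shown here alone, is whether a longer chain such as hex-1-en-1-yl would move the number beyond the scatter. The same question stands for a chain ending in an amine such as dimethylamino.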